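Chlorophenyl substitution pattern on the shared core

This account rests on a few compounds, and the source may have more. Where it says the series, first, only, none or still open, it means among the compounds named here.

Compound 1 `Clc1ccc(-c2cc(-c3ccsc3)nc(-c3ccccc3Cl)c2)o1` serves as the reference point for this step. In a functional assay on HCT-15 cells (Homo sapiens) for cytotoxicity, in the presence of a further agent that is not named here (on this read-out lower numbers stand for stronger inhibition and higher numbers for weaker inhibition), compound 1 gives 4570 nM, the lower of the two numbers recorded so far. Compound 2 `Cc1ccc(-c2cc(-c3ccoc3)cc(-c3ccsc3)n2)cc1` gives 44800 nM in this assay, a gap to compound 1 that lies beyond the scatter. Compound 3 `Clc1ccc(-c2cc(-c3ccco3)cc(-c3cccs3)n2)cc1` reaches only a limit of the assay, > 100000 nM in this assay, as shown by the limit of > 100000 nM in this assay, at which 1 of the 3 values shown sits. Going by the values given here, no pair of measured compounds differing in a single place is available, so the size of a one-place change on this core cannot be read from any comparable pair.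

Compound 4 `Clc1cccc(-c2cc(-c3ccc(Cl)o3)cc(-c3ccsc3)n2)c1` is still to be measured in this assay. It differs from compound 1 in one place: 3-chlorophenyl in place of 2-chlorophenyl on an aromatic carbon. The remainder of the shared core is unchanged. Among the compounds with values here, with no measured pair for this kind of change, the step from compound 1 is expected to be small and of no settled direction, roughly a 1.3-fold higher number from compound 1 to compound 4 (0.12 log units; within the scatter). Compound 4 is therefore estimated at about 6000 nM in this assay, with an expected range from 1500 nM to 25000 nM.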

Compound 4, half-maximal inhibitory concentration: 13700 nM
The estimate for compound 4 lay 2.3-fold (0.36 log units) below the measured number; low and high end bracket the measured number.
By their numbers in this assay, from the lowest: compound 1; then compound 4; then compound 2. At a limit, above all of these: compound 3.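

Going by these compounds alone, on the aromatic carbon next to the ring nitrogen, this is the first one-place step on the shared core in this assay, and it gives a 3.0-fold higher number from compound 1 to compound 4 (0.48 log units; beyond the scatter). With the atoms unchanged, moving the chlorine from 2-chlorophenyl to 3-chlorophenyl is enough to shift the number beyond the scatter, and the direction favours 2-chlorophenyl, since lower numbers stand for stronger inhibition here. No measured property among the data bears on why the number moves with this change.

A single step cannot show whether the direction would hold with the other groups on the shared core changed. On these data alone, whether an amine or a methoxy group in place of the chlorine on this phenyl ring would lower the number or raise it also remains open.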